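The source may hold more compounds than are shown below. What is called first, only, known or untested is meant among the compounds shown, and "the series" means these compounds.

In a functional assay on DU-145 cells (Homo sapiens) for antiproliferative activity, read by WST assay, with a stated time of 3 days (a lower number here means a stronger inhibitor, a higher number a weaker inhibitor), compound 1 `CCCOc1c(-c2cc(OC)c(OC)c(OC)c2)oc2ccccc2c1=O` gives 2800 nM. Compound 2 `CCCCCCCOc1c(-c2cc(OC)c(OC)c(OC)c2)oc2ccccc2c1=O` gives only a limit of the assay, > 50000 nM. Compound 3 `CCCN(CCC)CCCOc1c(-c2cc(OC)c(OC)c(OC)c2)oc2ccccc2c1=O` also gives only a limit, > 50000 nM. Compound 4 `CCCN(CCC)CCCCOc1c(-c2cc(OC)c(OC)c(OC)c2)oc2ccccc2c1=O` differs from compound 2 by dipropylamino in place of propyl on a saturated chain carbon, four bonds along the chain from an oxygen on an aromatic ring. Two large measured steps bear on this, an at least 17-fold higher number from compound 1 to compound 2 (1.25 log units; beyond the scatter) and an at least 17-fold higher number from compound 1 to compound 3 (1.25 log units; beyond the scatter), both towards weaker inhibition, while the third is a step that the two limits leave unreadable from compound 2 to compound 3. On these steps, compound 4 is expected to remain a weak inhibitor in this assay. The expected step, a number no higher from compound 2 to compound 4 (the limit leaves the size open), is estimated to lie within the scatter. For compound 4 the estimated value is 50000 nM, with an expected range of 20000 nM to 100000 nM.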

Compound 4, half-maximal inhibitory concentration: 35800 nM
Compound 4: the middle estimate sits 1.4-fold (0.15 log units) above what was measured, and the stated range covers the measured number.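

In this assay compound 4 gives a readable number, 35800 nM, so a dipropylamino chain end can now be sized against the short chain of compound 1: a 13-fold higher number from compound 1 to compound 4 (1.11 log units; beyond the scatter). The other two steps are an at least 1.3-fold lower number from compound 2 to compound 4 (0.14 log units; that floor lies within the scatter) and an at least 1.3-fold lower number from compound 3 to compound 4 (0.14 log units; that floor lies within the scatter), and with both floors within the scatter neither shows a real gain. How far those two steps reach stays open because compound 2 and compound 3 stand only at limits: the limit of > 50000 nM in this assay, at which 2 of the 4 values shown sit.

The compounds shown leave open whether a dimethylamino group, a morpholine ring or a carboxylic acid at the chain end would bring the number back towards that of compound 1.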